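This account rests on a few compounds, and the source may have more. Where it says the series, first, only, none or still open, it means among the compounds named here.

Of the compounds shown here, two have so far been measured in a functional assay on WM 266-4 cells (Homo sapiens) for antiproliferative activity, read by MTT assay, with a stated time of 48 h; a higher number here means a weaker inhibitor, a lower number a stronger inhibitor. Compound 1 `COc1ccc(C2=NN(c3nc(-c4ccc(C(F)(F)F)cc4)cs3)C(c3cccs3)C2)cc1` gives 8110 nM. Compound 2 `Fc1ccc(C2=NN(c3nc(-c4ccc(Br)cc4)cs3)C(c3cccs3)C2)cc1` gives 220 nM, the lower of the two numbers, and the gap to compound 1 lies well beyond the scatter. Within the data shown here, no step between measured compounds that differ in a single place is available. Compound 3 `Fc1ccc(C2=NN(c3nc(-c4ccc(C(F)(F)F)cc4)cs3)C(c3cccs3)C2)cc1` has not yet been measured; it differs from compound 2 by trifluoromethyl in place of bromo on an aromatic carbon. The expected step of a 4.5-fold higher number from compound 2 to compound 3 (0.66 log units; beyond the scatter) goes toward a higher number, beyond the scatter. For compound 3 the estimate is 1000 nM, within 300 nM to 4000 nM.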

Compound 3, half-maximal inhibitory concentration: 5120 nM
Beside the measured number, compound 3's estimate is 5.1-fold (0.71 log units) below it, and the stated range ends below it.
By their numbers in this assay, from the lowest: compound 2; then compounds 3 and 1 (each within the scatter of the next).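

In this assay, trifluoromethyl in place of bromo gives the first step read at a single place, a 23-fold higher number from compound 2 to compound 3 (1.37 log units; beyond the scatter), so this aromatic carbon is sensitive to its substituent. With trifluoromethyl held there, fluoro in place of methoxy gives a 1.6-fold lower number from compound 1 to compound 3 (0.20 log units; within the scatter), which does not separate the two compounds. Nothing available bears on why the first step is so large.

From the compounds shown here alone, whether other groups at this carbon, such as chloro or an amine, stay close to bromo remains open. Also open, going by these compounds, is whether fluoro and methoxy remain inseparable with bromo in place of trifluoromethyl.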